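Adding a Second Chlorine to an Adenosine A3 Binder

A few compounds are considered here, and "the series" means these few. Any claim that something is new, unique, unknown or untested is made for them only; others in the source may bear on it.

Of the compounds shown here, three have been tested in an assay on cells for displacement of a labelled ligand from adenosine receptor A3 (Homo sapiens), read by scintillation counting and radioligand binding, with a stated time of 180 min, tested at 10 uM; a higher number here means more inhibition at the concentration tested (going by the name of the read-out), a lower number less inhibition. Compound 1, with the structure `Oc1cccc(-c2nc(N3CCCCC3)c3nc[nH]c3n2)c1`, reaches only a limit of the assay, > 80%. Compound 2, with the structure `CN1CCN(c2nc(-c3cccc(Cl)c3)nc3[nH]cnc23)CC1`, also reaches only a limit, > 80%. Both sit at the limit of > 80% in this assay, at which 2 of the 3 values shown sit, so no number separates them. Among the compounds with values here, compound 3, with the structure `Cn1cnc2c(N3CCCCC3)nc(-c3ccccc3Cl)nc21`, is the only one with an actual number: in this assay compound 3 gives 2.1%, which means almost no displacement of the labelled ligand at the concentration tested. No pair of these compounds differs in a single place, so no measured step can be drawn between them.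

Compound 4, with the structure `Cn1cnc2c(N3CCCCC3)nc(-c3cc(Cl)ccc3Cl)nc21`, has not yet been measured. It differs from compound 3 by chloro in place of hydrogen on an aromatic carbon, which turns the 2-chlorophenyl of compound 3 into a 2,5-dichlorophenyl. Within the data shown here, with no measured step of this kind to draw on, the expectation is a step of a number 7.9 percentage points higher from compound 3 to compound 4 (within the scatter), that is, hardly any change beyond the scatter, so the inhibition read for compound 4 is expected to stay about level. In this assay compound 4 is estimated to give 10%, with a likely range from 0% to 40%.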

Compound 4, a percentage reported as inhibition, at one concentration (the size of the read-out at that concentration, not a potency): 5.4%
For compound 4 the middle estimate is 4.6 percentage points above the measured one; the measured number falls inside the stated range.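

Within the data shown here, this is the only measured step so far: in this assay, placing a chloro in place of hydrogen on an aromatic carbon, meta to a large group and para to a chloro group, gives a number 3.3 percentage points higher from compound 3 to compound 4 (within the scatter) on the shared core. At this position, then, the 2,5-dichlorophenyl of compound 4 cannot be told apart from the 2-chlorophenyl of compound 3 in this read-out. Nothing measured here speaks to why the second chlorine leaves the reading where it is.

Still open, on these data alone, is whether another group at this same place, such as a methoxy group, an amine or a carboxylic acid, would read differently. Also open is what the methyl group shared by compound 3 and compound 4 contributes, as no pair shown differs by that group alone.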